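Series notes: aryl exchange at the saturated ring carbon

The source may hold more compounds than are shown below. What is called first, only, known or untested is meant among the compounds shown, and "the series" means these compounds.

Of the compounds shown here, two have been measured in a functional assay on HEK293 cells for agonist activity at D(4) dopamine receptor (Homo sapiens), read by FLIPR; a higher number here means that more compound is needed for the effect, a lower number that less compound is needed. Compound 1 `COc1ccccc1C1CCN(CC(=O)Nc2cccc(C)c2)CC1` gives 420 nM, the higher of the two numbers. Compound 2 `COc1cc(C(=O)NCN2CCC(c3cccc[n+]3[O-])CC2)ccc1Cl` gives 159 nM, and the gap between these two values lies beyond the scatter. Compound 3 `Cc1cccc(NC(=O)CN2CCC(c3cccc(C#N)n3)CC2)c1` has not been measured in this assay. It differs from compound 1 in one place: 6-cyanopyridin-2-yl in place of 2-methoxyphenyl on a saturated ring carbon. For the measured compounds named here, no step of this kind between measured compounds is known, so the direction is open. The step from compound 1 to compound 3 is expected to be a 1.1-fold higher number from compound 1 to compound 3 (0.03 log units; within the scatter), within the scatter or only a little beyond it. Compound 3 is estimated at 450 nM, with a range from 150 nM to 1400 nM.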

Compound 3, half-maximal effective concentration: 36 nM
Estimate against measurement, compound 3: 13-fold (1.10 log units) above; the measured number lies below the stated range.
By their numbers in this assay, from the lowest: compound 3; then compound 2; then compound 1.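

The group on the saturated ring carbon strongly affects the number in this assay: exchanging 2-methoxyphenyl for 6-cyanopyridin-2-yl gives a 12-fold lower number from compound 1 to compound 3 (1.07 log units; beyond the scatter). Both groups hold 8 heavy atoms, so the step comes from a change in the make-up of the group and not from a change in its heavy-atom count. No available evidence bears on why the step is this large.

Still open, going by these compounds, is whether the step follows the nitrile, the ring nitrogen or the loss of the methoxy group. A cyanophenyl or plain pyridin-2-yl group on the same core would help separate these.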